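Extending the ethylsulfonyl chain by one carbon: an expectation

A few compounds are considered here, and "the series" means these few. Any claim that something is new, unique, unknown or untested is made for them only; others in the source may bear on it.

Compound 1, `CCCSc1nnc(COc2cc(C)c3c(C)cc(=O)oc3c2)o1`, gives > 100000 nM in a functional assay on MCF7 cells (Homo sapiens) for antiproliferative activity, read by MTT assay, with a stated time of 24 h (on this read-out higher numbers stand for weaker inhibition and lower numbers for stronger inhibition), a limit of the assay rather than a number.
Compound 2, `CCCCSc1nnc(COc2cc(C)c3c(C)cc(=O)oc3c2)o1`, gives > 100000 nM in this assay, again a limit.
Compound 3, `CCS(=O)(=O)c1nnc(COc2cc(C)c3c(C)cc(=O)oc3c2)o1`, gives > 100000 nM in this assay, also a limit.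

The step that the two limits leave unreadable from compound 1 to compound 2 is made by methyl in place of hydrogen on a saturated chain carbon, three bonds along the chain from a sulfur. Compound 4, `CCCS(=O)(=O)c1nnc(COc2cc(C)c3c(C)cc(=O)oc3c2)o1`, has not yet been measured and differs from compound 3 by methyl in place of hydrogen on a saturated chain carbon, two bonds along the chain from a sulfonyl sulfur. This is the same kind of change, but the place differs: in the first pair the carbon is three bonds along the chain from a sulfur, in the second two bonds along the chain from a sulfonyl sulfur. The cores of the two pairs differ by ethylsulfonyl in place of propylsulfanyl on an aromatic carbon. Going by the values given here, because all values sit at the limit of > 100000 nM in this assay, at which 3 of the 3 values shown sit, no measured step reveals any effect of the change. The step that the limit leaves unreadable from compound 3 to compound 4 is expected to stay unreadable. Compound 4 is expected to give 150000 nM in this assay, most likely reported only as a limit.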

Compound 4, half-maximal inhibitory concentration: > 100000 nM
Compound 4 ended at the assay's limit (the forecaster's own chance of this, stated with the estimate: 85%); the middle value does not contradict the limit.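

Going by these compounds alone, no step among compound 1, compound 2, compound 3 and compound 4 can be read, because all four stop at the same limit: the limit of > 100000 nM in this assay, at which 4 of the 4 values shown sit.

Going by these compounds, whether any of these side chains affects activity in this assay stays open.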